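Phenyl for hydrogen on the side chain of compound 2

The source may report more compounds than this note shows. Statements on the series, on what has been measured and on what is new or still open speak of the compounds shown alone.

Measured compounds:
compound 1, `COc1ccc2c(c1)[n+]([O-])nc(NCOC(C)c1ccccc1)[n+]2[O-]`: 4140 nM
compound 2, `CCOCNc1n[n+]([O-])c2ccccc2[n+]1[O-]`: 15900 nM

Two compounds carry numbers in a functional assay on PC-3 cells (Homo sapiens) for cytotoxicity, read by MTT assay, with a stated time of 72 h; a higher number here means a weaker inhibitor, a lower number a stronger inhibitor. Compound 1 gives 4140 nM. Compound 2 gives 15900 nM, the higher of the two numbers, and the gap to compound 1 lies beyond the scatter. For the measured compounds named here, compound 1 differs from compound 2 in more than one place, so no single step is read from that pair.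

Compound 3, `CC(OCNc1n[n+]([O-])c2ccccc2[n+]1[O-])c1ccccc1`, has not yet been measured in this assay. It differs from compound 2 by phenyl in place of hydrogen on a saturated chain carbon bound to an oxygen on a saturated carbon and a saturated chain carbon. Compound 1 carries the same side chain as compound 3 on a core that also bears a methoxy group, and its number sits well under that of compound 2; from this alone a step toward a lower number is the most plausible outcome for compound 3, though with a single reference pair the size is uncertain and a result within the scatter cannot be excluded.

The number for compound 3 is expected to fall near 5500 nM, with a range of 1800 nM to 17000 nM. This estimate means a step from compound 2 to compound 3 of a 2.9-fold lower number from compound 2 to compound 3 (0.46 log units; beyond the scatter).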

Compound 3, half-maximal inhibitory concentration: 6080 nM
Estimate against measurement, compound 3: 1.1-fold (0.04 log units) below, and the stated range covers the measured number.
By their numbers in this assay, from the lowest: compounds 1 and 3 (each within the scatter of the next); then compound 2.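

In this assay, for the compounds shown here, phenyl in place of hydrogen on a saturated chain carbon bound to an oxygen on a saturated carbon and a saturated chain carbon gives a 2.6-fold lower number from compound 2 to compound 3 (0.42 log units; beyond the scatter), the first single-place reading at this position. Hydrogen in place of methoxy on an aromatic carbon gives a 1.5-fold higher number from compound 1 to compound 3 (0.17 log units; within the scatter), so the gap between compound 1 and compound 2, which could not be read as one step, now divides into two single-place steps, of which only the phenyl step lies beyond the scatter. No independent measurement bears on why the phenyl step occurs.

As far as these compounds go, whether this step belongs to phenyl as an aromatic ring, or to added carbon on the chain, remains open; a cyclohexyl ring, a pyridine ring or a longer chain on the same carbon would separate these readings. From the compounds shown here alone, on the aromatic carbon, only methoxy and hydrogen can be compared, so the effect of a chlorine atom or an amine there, and whether the phenyl step holds on other cores, remains unknown.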